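Alkoxy chain length on the shared core: extension to octyl

This account rests on a few compounds, and the source may have more. Where it says the series, first, only, none or still open, it means among the compounds named here.

Measured in a functional assay on DLD-1 cells (Homo sapiens) for cytotoxicity, read by MTT assay, with a stated time of 48 h; on this read-out lower numbers stand for stronger inhibition and higher numbers for weaker inhibition:
compound 1 `CN(C)CCNc1ccnc2cc(OCc3ccc(F)cc3)ccc12`: 810 nM
compound 2 `CC(C)COc1ccc2c(Cl)ccnc2c1`: 3100 nM
compound 3 `CCCCOc1ccc2c(Cl)ccnc2c1`: 3780 nM

Compound 3 and compound 2 lie within the scatter of each other; compound 1 sits beyond the scatter at a lower number than compound 3. Compound 4 `CCCCCCCCOc1ccc2c(Cl)ccnc2c1` differs from compound 3 by butyl in place of hydrogen on a saturated chain carbon, four bonds along the chain from an oxygen on an aromatic ring. Within the data shown here, the only chain step measured so far is a 1.2-fold higher number from compound 2 to compound 3 (0.09 log units; within the scatter), a small change. Among the measured compounds shown here, no step covers a chain as long as octyl, so the expectation for compound 4 rests on that one small step alone. For compound 4 the estimate is a 1.3-fold lower number from compound 3 to compound 4 (0.10 log units; within the scatter), no shift beyond the scatter, with a wide range because of the lack of data. Compound 4 is therefore expected at 3000 nM, between 800 nM and 11000 nM.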

Compound 4, half-maximal inhibitory concentration: 4500 nM
Estimate against measurement, compound 4: 1.5-fold (0.18 log units) below; the range from low to high includes it.
By their numbers in this assay, from the lowest: compound 1; then compounds 2, 3 and 4 (each within the scatter of the next).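

At this chain position, the shared core tolerates a large extension: going to octyl in this assay gives only a small step (a 1.2-fold higher number from compound 3 to compound 4 (0.08 log units; within the scatter)). The earlier step covered only propyl in place of isopropyl, so this result extends the flat stretch to a much longer chain. Across compounds 2, 3 and 4, no chain change moves the number beyond the scatter.

Open, from the compounds shown here alone, is whether a chain longer than octyl, or an amine or a carboxylic acid at its end, would produce a step beyond the scatter on this core. No measurement shown here accounts for the flat response to chain length.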